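Sulfonamide in place of the aryl ether on the chain

A few compounds are considered here, and "the series" means these few. Any claim that something is new, unique, unknown or untested is made for them only; others in the source may bear on it.

Compound 2 `COC(=O)c1c(F)cccc1-c1ccc(CCc2ncc(CC(C)(C)C)n2CCOc2cccc(O)c2)cc1` gives 13 nM in an assay on cells for agonist activity at Bombesin receptor subtype-3 (Homo sapiens), read by HTRF and inositol phosphate accumulation, with a stated time of 1 h (on this read-out higher numbers stand for an effect only at larger amounts of compound and lower numbers for an effect already at smaller amounts), and holds the lowest of the two numbers measured; its nearest neighbour is compound 1 `COC(=O)c1c(F)cccc1-c1ccc(CCc2ncc(CC(C)(C)C)n2CCO)cc1` with 21 nM in this assay, and the step of a 1.6-fold lower number from compound 1 to compound 2 (0.21 log units; within the scatter) lies within the scatter. That step is the only one touching the end of the hydroxyethyl chain: a 3-hydroxyphenyl on the oxygen in place of hydrogen left the number essentially where it was.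

Compound 3 `COC(=O)c1c(F)cccc1-c1ccc(CCc2ncc(CC(C)(C)C)n2CCNS(C)(=O)=O)cc1` is not yet measured. The change from compound 2 is methanesulfonamido in place of 3-hydroxyphenoxy on a saturated chain carbon, two bonds along the chain from an aromatic nitrogen. Going by the values given here, the single relevant step, from compound 1 to compound 2, was within the scatter, so the chain end appears to tolerate both a bare hydroxyl and a sizeable aryl ether without a shift; on that basis the step from compound 2 to compound 3 is expected to be none beyond the scatter, with a 1.5-fold higher number from compound 2 to compound 3 (0.19 log units; within the scatter) as the working expectation. Among the compounds with values here, compound 3 is therefore estimated at 20 nM, within 7 nM to 60 nM, the wide range reflecting that only two measurements exist.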

Compound 3, half-maximal effective concentration: 11 nM
Estimate against measurement, compound 3: 1.8-fold (0.26 log units) above, and the stated range covers the measured number.
By their numbers in this assay, from the lowest: compounds 3, 2 and 1 (each within the scatter of the next).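

In this assay, the chain end also accepts a group with no ring: methanesulfonamido in place of 3-hydroxyphenoxy gives a 1.2-fold lower number from compound 2 to compound 3 (0.07 log units; within the scatter), and methanesulfonamido in place of hydroxy gives a 1.9-fold lower number from compound 1 to compound 3 (0.28 log units; within the scatter). Hydroxy, 3-hydroxyphenoxy and methanesulfonamido on this saturated chain carbon thus all lie within the scatter of one another, even though the entering methanesulfonamido has 5 heavy atoms, including sulfur and nitrogen, where the leaving 3-hydroxyphenoxy has 8 and an aromatic ring. No supporting evidence is available to explain this flat response.

Still open, as far as these compounds go, is whether any end group on this chain moves the number beyond the scatter, as every step here stays within it; a primary amine, a carboxylic acid or a longer chain in place of 2-(methanesulfonamido)ethyl would put that to the test. All three compounds also share the same core, leaving open whether this tolerance at the chain end would hold with a carboxylic acid in place of the methyl ester.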